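Swapping Bromo for Methyl on a Shared Core

The compounds below may be only part of what the source reports. "The series", "measured", "known", "first", "only" and "open" are said of these compounds alone.

Of the compounds shown here, two with a shared core have been measured in a physicochemical assay for lipophilicity, in phosphate buffer, measured as octanol-water partition, with a stated time of 24 h; on this read-out higher numbers stand for higher lipophilicity and lower numbers for lower lipophilicity. In this assay compound 1 `O=C(CSc1nc2ccccc2s1)N/N=C/c1ccc(Oc2ccccc2)cc1` gives 5.6. Compound 2 `Brc1ccc(Oc2ccc(/C=N/Nc3nc4ccccc4s3)cc2)cc1` gives 5.5 in this assay; its number differs from that of compound 1 by less than the usual scatter of repeated measurements, so the two cannot be told apart on this read-out, and compound 2 sits alongside compound 1 rather than clearly under it.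

Compound 3 `Cc1ccc(Oc2ccc(/C=N/Nc3nc4ccccc4s3)cc2)cc1` has not yet been measured. It differs from compound 2 in one place: methyl in place of bromo on an aromatic carbon. No measured pair among these compounds shows this kind of exchange, so there is no step to lean on. Compound 3 is expected to come out a little lower in this assay, and the expected step of a number 0.30 log units lower from compound 2 to compound 3 (within the scatter) is small, close to the edge of the scatter. Compound 3 is therefore estimated at 5.2, with a range from 4.8 to 5.6.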

Compound 3, partition coefficient: 5.4
Estimate against measurement, compound 3: 0.20 log units below, and the stated range covers the measured number.
By their numbers in this assay, from the lowest: compounds 3, 2 and 1 (each within the scatter of the next).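

For the compounds shown here, this is the first measured pair in the set that shows this exchange. In this assay, methyl in place of bromo on an aromatic carbon, para to a large group, gives a number 0.10 log units lower from compound 2 to compound 3 (within the scatter), so 4-bromophenoxy and 4-methylphenoxy cannot be told apart on this read-out in this one pair. Nothing measured here explains why these two groups read alike.

The compounds shown leave open whether an amine or a carboxylic acid on this same aromatic carbon would give a number clearly apart from that of compound 2. They also leave open whether the exchange of bromo for methyl would stay within the scatter on another aromatic carbon or on a different core, such as the core of compound 1.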